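The source may report more compounds than this note shows. Statements on the series, on what has been measured and on what is new or still open speak of the compounds shown alone.

In a functional assay on NCI-H460 cells (Homo sapiens) for positive allosteric modulation, read by MTT assay, with stated times of 2 h and 72 h, tested at 3 uM (a lower number here means a stronger inhibitor, a higher number a weaker inhibitor), three compounds sharing one core have been measured. Compound 1 (`CCCc1ccc(C(=O)Nc2ccccc2-c2nnn(-c3cccc(OC)c3)n2)cc1`) gives 173 nM, compound 2 (`COc1cccc(-n2nnc(-c3ccccc3NC(=O)c3ccc(N=[N+]=[N-])cc3)n2)c1`) gives 455 nM, and compound 3 (`COc1cccc(-n2nnc(-c3ccccc3NC(=O)c3ccc(NC(=O)CBr)cc3)n2)c1`) gives 175 nM. The numbers show a 1.0-fold higher number from compound 1 to compound 3 (0.00 log units; within the scatter), and also a 2.6-fold lower number from compound 2 to compound 3 (0.41 log units; beyond the scatter). Compound 3 therefore shares the lower end of this small range with compound 1, and compound 2 alone lies higher.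

Compound 4 (`COc1cccc(-n2nnc(-c3ccccc3NC(=O)Nc3ccc([N+](=O)[O-])cc3)n2)c1`) carries (4-nitrophenyl)amino in place of 4-(((bromomethyl)carbonyl)amino)phenyl on a carbonyl carbon. The three measured steps bear on this only loosely. Each swaps one group on an aromatic carbon, and even a 2.6-fold higher number from compound 1 to compound 2 (0.42 log units; beyond the scatter) is only modest. Among the compounds with values here, none of them changes what sits directly on the carbonyl carbon, and no measured compound carries a nitro group, so the direction stays open.

In this assay, the expected change is therefore small, and the estimate is a 1.4-fold higher number from compound 3 to compound 4 (0.15 log units; within the scatter). For compound 4 the estimated value is 250 nM, with an expected range from 80 nM to 800 nM.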

Compound 4, half-maximal inhibitory concentration: 190 nM
The estimate for compound 4 lay 1.3-fold (0.12 log units) above the measured number; the measured number falls inside the stated range.
By their numbers in this assay, from the lowest: compounds 1, 3 and 4 (each within the scatter of the next); then compound 2.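

Replacing the whole group on the carbonyl carbon, rather than only a group on an aromatic carbon, gives numbers that cannot be told apart in this assay: the data show a 1.1-fold higher number from compound 3 to compound 4 (0.04 log units; within the scatter), and also a 1.1-fold higher number from compound 1 to compound 4 (0.04 log units; within the scatter). Compound 2, with its azido group, remains apart from this cluster, as the data show a 2.4-fold lower number from compound 2 to compound 4 (0.38 log units; beyond the scatter), a modest step. So, among these compounds, (4-nitrophenyl)amino on this carbonyl carbon serves as well as the 4-(((bromomethyl)carbonyl)amino)phenyl group, and no measured evidence here explains why.

As far as these compounds go, it remains open whether an aromatic ring is needed on this carbonyl carbon at all, as a plain amine or a short alkyl chain there could show. From the compounds shown here alone, it also remains open whether the nitro group matters, which a carboxylic acid in its place could help to reveal.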